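Series notes: removing one methyl from compound 2

The source may report more compounds than this note shows. Statements on the series, on what has been measured and on what is new or still open speak of the compounds shown alone.

The series shares a core seen in compound 1 `COc1ccccc1-c1cccc(S(=O)(=O)N2CCC(N3CCC(C)CC3)CC2)c1` and compound 2 `Cc1ccc(S(=O)(=O)N2CCC(N3CCC(C)CC3)CC2)cc1C`, the two differing in one part of the molecule. In an ADME assay on HCT-116 cells (Homo sapiens) for cytotoxicity, read by CellTiter-Glo, with a stated time of 72 h (a lower number here means a stronger inhibitor, a higher number a weaker inhibitor), compound 1 gives only a limit of the assay, > 5000 nM. In this assay compound 2 likewise returns a limit and no number, > 5000 nM. Compound 2 therefore stands at the limit, and no ordering of the two measured compounds can be drawn, since (the limit of > 5000 nM in this assay, at which 2 of the 2 values shown sit). The next compound, compound 3 `Cc1cccc(S(=O)(=O)N2CCC(N3CCC(C)CC3)CC2)c1`, is to be measured in this assay. It is reached from compound 2 by hydrogen in place of methyl on an aromatic carbon. For the measured compounds named here, no measured pair differs at this one place, so no measured step guides the expectation. With both measured values sitting at the limit, the step from compound 2 to compound 3 in this assay is expected to be a step that the limit leaves unreadable from compound 2 to compound 3, and it is not expected to exceed the scatter. Compound 3 is expected to give 8000 nM in this assay, within a range from 3000 nM to 20000 nM, most likely reported again as a limit only.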

Compound 3, half-maximal inhibitory concentration: > 5000 nM
Compound 3 was reported as a limit; the forecaster's own chance of this, stated with the estimate: 85%; the middle value is on the limit's open side.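

No step from compound 1 or compound 2 to compound 3 can be read in this assay, because all three compounds return only a limit: the limit of > 5000 nM in this assay, at which 3 of the 3 values shown sit.

The compounds shown leave open whether the methyl or the 2-methoxyphenyl group has any bearing on the read-out in this assay, and what number any of the three compounds would give.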